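Adding a methoxy to compound 1: cytotoxicity notes

The compounds below may be only part of what the source reports. "The series", "measured", "known", "first", "only" and "open" are said of these compounds alone.

In an ADME assay on L6 cells (Rattus norvegicus) for cytotoxicity (on this read-out higher numbers stand for weaker inhibition and lower numbers for stronger inhibition), compound 1 (`CC(C)NC(=N)c1cccc(-c2cc3ccc(C(=N)NC(C)C)cc3o2)c1`) gives no number, only a limit of > 200000 nM. Compound 3 (`CC(C)NC(=N)c1ccc(-c2cc3cc(C(=N)NC(C)C)ccc3o2)c(O)c1`) also gives only a limit, > 183000 nM. Compound 2 (`COc1cc(C2=NCCN2)cc2cc(-c3ccc(C4=NCCN4)cc3)oc12`) gives a measured value of 19900 nM.

Compound 4 (`COc1ccc(C(=N)NC(C)C)cc1-c1cc2ccc(C(=N)NC(C)C)cc2o1`) is compound 1 with methoxy in place of hydrogen on an aromatic carbon, ortho to a large group and para to a group of 6 heavy atoms: methoxy in place of hydrogen on an aromatic carbon.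

Among the measured compounds shown here, no measured pair isolates this change. Compound 2 also carries a methoxy and gives 19900 nM, but it differs from compound 1 in more than one place, so it offers only weak guidance. A small shift towards stronger inhibition is therefore the working expectation in this assay. The estimated step is an at least 1.6-fold lower number from compound 1 to compound 4 (0.22 log units; that floor lies within the scatter). A reported limit instead of a number would be no surprise. For compound 4 the estimated value is 120000 nM, with an expected range of 40000 nM to 250000 nM.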

Compound 4, half-maximal inhibitory concentration: > 175000 nM
Compound 4 gave a limit, no number (the forecaster's own chance of this, stated with the estimate: 45%); middle value at least 1.4-fold (0.16 log units) from the limit.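

In this assay, among the compounds shown here, compound 1 and compound 4 both give only limits, and no step between the two can be read. The compounds shown leave open whether methoxy in place of hydrogen on an aromatic carbon changes the read-out at all, and in which direction.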